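Removing one methoxy group: cytotoxicity read-out in two cores

The compounds below may be only part of what the source reports. "The series", "measured", "known", "first", "only" and "open" are said of these compounds alone.

Compound 1 `COc1ccc(-c2cc(/C=C/C(=O)c3ccc(N)cc3)[nH]n2)cc1` and compound 2 `COc1ccc(-c2cc(/C=C/C(=O)c3ccc(N)cc3)[nH]n2)cc1OC` share one core. In a functional assay on IGROV-1 cells (Homo sapiens) for cytotoxicity, read by sulforhodamine B assay, with a stated time of 48 h, tested at 10 uM (on this read-out lower numbers stand for a stronger effect and higher numbers for a weaker effect at the one concentration tested), compound 1 gives -21%, and compound 2 gives 24%. Between them stands the change (hydrogen in place of methoxy on an aromatic carbon), which produced a number 45 percentage points lower from compound 2 to compound 1 (beyond the scatter). Compound 3 `COc1cc(C(=O)/C=C/c2cc(-c3cc(OC)c(OC)c(OC)c3)n[nH]2)cc(OC)c1OC` is built on a different core; the difference between the two cores is not broken down here. In this assay compound 3 gives 1%. Compound 4 `COc1ccc(-c2cc(/C=C/C(=O)c3cc(OC)c(OC)c(OC)c3)[nH]n2)cc1OC` derives from compound 3 through (hydrogen in place of methoxy on an aromatic carbon). This is the same kind of change as seen between compound 2 and compound 1, though here the place is also meta to a methoxy group. Resting on a number 45 percentage points lower from compound 2 to compound 1 (beyond the scatter) as the only precedent, and allowing that the core differs, the step from compound 3 to compound 4 in this assay is expected to be a number 26 percentage points lower from compound 3 to compound 4 (beyond the scatter). Compound 4 is accordingly estimated at -25%, expected to fall between -55% and 10%.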

Compound 4, a percentage reported as activity, at one concentration (the size of the read-out at that concentration, not a potency): -7%
Compound 4: the middle estimate sits 18 percentage points below what was measured, within the range that was stated.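

In this assay, hydrogen in place of methoxy gives a number 8 percentage points lower from compound 3 to compound 4 (within the scatter), so the step seen on the core of compound 1 does not recur at the same size on the core of compound 3: the same change on two cores in this assay, a number 45 percentage points lower (beyond the scatter) from compound 2 to compound 1 and a number 8 percentage points lower (within the scatter) from compound 3 to compound 4, 37 percentage points apart, beyond the scatter of two such steps. In this series, the size of the step on one core therefore cannot simply be carried to the other. Two pairs do not show whether the core itself or the surroundings of the changed place account for the gap, nor how the change would behave on any further core.

The compounds shown carry only methoxy or hydrogen at the changed place. On these data alone, how a hydroxyl, a fluorine or a longer alkoxy chain there would read on either core remains open.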